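Aryl change on the ring nitrogen: compound 3 to compound 4

A few compounds are considered here, and "the series" means these few. Any claim that something is new, unique, unknown or untested is made for them only; others in the source may bear on it.

Measured so far in a functional assay on MG-63 cells (Homo sapiens) for inhibition, read by CCK-8 assay, with a stated time of 72 h, tested at 1 uM; on this read-out higher numbers stand for more inhibition at the one concentration tested (going by the name of the read-out) and lower numbers for less inhibition:
- compound 1 `O=C(NCCCCc1ccccc1)c1cccc(C2OCC(=O)N2c2cccc(F)c2)c1` gives 66%
- compound 2 `CCOc1ccccc1N1C(=O)C(C)SC1c1cccc(C(=O)NCCCCc2ccccc2)c1` gives 92%
- compound 3 `COc1c(F)cccc1N1C(=O)CSC1c1cccc(C(=O)NCCCCc2ccccc2)c1` gives 0%

Compound 3 stands lowest of the three, below both compound 1 and compound 2 by margins beyond the usual scatter, with compound 1 the nearer of the two and compound 2 the further. For the measured compounds named here, no two measured compounds differ in a single place, so no step within the measured set can be read off; compound 2 and compound 3 differ in more than one place.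

Compound 4 `COc1ccc(N2C(=O)CSC2c2cccc(C(=O)NCCCCc3ccccc3)c2)c(OC)c1` is not yet measured. It differs from compound 3 in one place: 2,4-dimethoxyphenyl in place of 3-fluoro-2-methoxyphenyl on an amide-type nitrogen in a ring. Going by the values given here, no measured pair isolates this change. Among the compounds with values here, the only measured compound whose aryl on the ring nitrogen lacks fluorine, compound 2, gives 92% in this assay, which leaves room for a rise, though other differences accompany it.

The step from compound 3 to compound 4 is expected to be upward, a number 40 percentage points higher from compound 3 to compound 4 (beyond the scatter), beyond the scatter but uncertain in size. Compound 4 is expected to give 40%, within a range of 5% to 85%.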

Compound 4, a percentage reported as inhibition, at one concentration (the size of the read-out at that concentration, not a potency): 56%
For compound 4 the middle estimate is 16 percentage points below the measured one; the range from low to high includes it.
By their numbers in this assay, from the lowest: compound 3; then compounds 4 and 1 (each within the scatter of the next); then compound 2.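

In this assay, for the compounds shown here, the aryl on the amide-type nitrogen in the ring is the first place where a single change can be read: 2,4-dimethoxyphenyl in place of 3-fluoro-2-methoxyphenyl gives a number 56 percentage points higher from compound 3 to compound 4 (beyond the scatter), a large step. The reading of compound 3 is therefore not fixed by the shared core, since this aryl alone is enough to move the inhibition at the one concentration tested. No measurement at hand accounts for the step.

The change removes the fluorine and brings in a second methoxy in a single move, so the share of each in the step stays unresolved. Also open, going by these compounds, is how this position responds to an aryl bearing a dimethylamino group or a carboxylic acid.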